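A few compounds are considered here, and "the series" means these few. Any claim that something is new, unique, unknown or untested is made for them only; others in the source may bear on it.

In a functional assay on cardiac atrium (Cavia porcellus) (a higher number here means that more compound is needed for the effect, a lower number that less compound is needed), two compounds sharing the same core have been measured so far. Compound 1 `COC(=O)C1=C(C)NC(C)=C(C(=O)OC)C1c1c(-c2ccccn2)nc2sccn12`, which carries pyridin-2-yl, gives 24400 nM, and compound 2 `COC(=O)C1=C(C)NC(C)=C(C(=O)OC)C1c1c(-c2cccnc2)nc2sccn12`, which carries pyridin-3-yl, gives 28400 nM. For the measured compounds named here, compound 2 therefore stands level with compound 1, the only compound it can be compared with.

The next compound is compound 3 `COC(=O)C1=C(C)NC(C)=C(C(=O)OC)C1c1c(-c2ccsc2)nc2sccn12`, with thiophen-3-yl in place of pyridin-3-yl on an aromatic carbon. Going by the values given here, only one measured step bears on this change, and it concerns the same aromatic carbon: a 1.2-fold higher number from compound 1 to compound 2 (0.07 log units; within the scatter). That step is a weak guide, since both of its groups are six-membered aromatic rings, while compound 3 brings in a five-membered aromatic ring with a sulfur. Among the compounds with values here, no measured compound yet shows what such a ring does here. The expectation in this assay is thus no step beyond the scatter, in either direction, but with wide uncertainty. The estimated step is a 1.1-fold lower number from compound 2 to compound 3 (0.04 log units; within the scatter). For compound 3, the expected value is 26000 nM, with an estimated range from 9000 nM to 75000 nM.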

Compound 3, half-maximal effective concentration: 1060 nM
The estimate for compound 3 lay 25-fold (1.39 log units) above the measured number; the whole stated range lies above it.
By their numbers in this assay, from the lowest: compound 3; then compounds 1 and 2 (each within the scatter of the next).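

In this assay, the group on this aromatic carbon of the five-membered ring clearly matters, which the two earlier compounds could not show: moving the ring nitrogen from pyridin-2-yl to pyridin-3-yl left the number within the scatter. Thiophen-3-yl in place of pyridin-3-yl brings a 27-fold lower number from compound 2 to compound 3 (1.43 log units; beyond the scatter), and thiophen-3-yl in place of pyridin-2-yl brings a 23-fold lower number from compound 1 to compound 3 (1.36 log units; beyond the scatter), so far less compound is needed for the effect once the six-membered aromatic ring gives way to this five-membered one. Nothing available here explains why this exchange of rings has so large an effect.

The change alters ring size and replaces the ring nitrogen with sulfur in a single step, so the compounds shown cannot separate these two differences. A phenyl ring would show what a six-membered ring without nitrogen does at this carbon, while furan-3-yl or thiophen-2-yl would show whether the step depends on the sulfur or on where it sits in the ring.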